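A few compounds are considered here, and "the series" means these few. Any claim that something is new, unique, unknown or untested is made for them only; others in the source may bear on it.

Measured so far:
compound 1, `CC(C)=CC(=O)Nc1c(C(O)(C(F)(F)F)C(F)(F)F)ccc2ccccc12`: 46 nM
compound 2, `C/C=C/C(=O)Nc1c(C(O)(C(F)(F)F)C(F)(F)F)ccc2ccccc12`: 72 nM
compound 3, `O=C(Nc1c(C(O)(C(F)(F)F)C(F)(F)F)ccc2ccccc12)c1ccc(I)cc1`: 154 nM

These three compounds share the same core and differ only in the group attached to the carbonyl carbon. In an assay on LtK cells with ATP-sensitive inward rectifier potassium channel 11 (Homo sapiens) as the target (a higher number here means that more compound is needed for the effect, a lower number that less compound is needed), compound 3 gives 154 nM, the highest of the three numbers, so the most compound is needed with it; the step of a 2.1-fold higher number from compound 2 to compound 3 (0.33 log units; beyond the scatter) and the step of a 3.3-fold higher number from compound 1 to compound 3 (0.52 log units; beyond the scatter) both lie beyond the scatter, while the step of a 1.6-fold higher number from compound 1 to compound 2 (0.19 log units; within the scatter) does not. The next compound, compound 4 `O=C(Nc1c(C(O)(C(F)(F)F)C(F)(F)F)ccc2ccccc12)c1ccc(C(F)(F)F)cc1`, differs from compound 3 in a single place: trifluoromethyl in place of iodo on an aromatic carbon. Within the data shown here, none of the measured steps covers an exchange of this kind, since each of them swaps the whole group on the carbonyl carbon rather than one substituent on a ring. With nothing to lean on, the expectation for compound 4 in this assay is a step within the scatter, in no firm direction: a 1.0-fold lower number from compound 3 to compound 4 (0.01 log units; within the scatter). Compound 4 is therefore estimated at 150 nM, with a range from 60 nM to 400 nM.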

Compound 4, half-maximal effective concentration: 160 nM
Beside the measured number, compound 4's estimate is 1.1-fold (0.03 log units) below it; low and high end bracket the measured number.
By their numbers in this assay, from the lowest: compounds 1 and 2 (each within the scatter of the next); then compounds 3 and 4 (each within the scatter of the next).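

In this assay, putting trifluoromethyl in place of iodo on the aromatic ring gives a 1.0-fold higher number from compound 3 to compound 4 (0.02 log units; within the scatter) so at this position, a group of 4 heavy atoms can replace a single iodine without a readable change. The 4-(trifluoromethyl)phenyl group also stays apart from the two smaller groups on the carbonyl carbon, with a 2.2-fold higher number from compound 2 to compound 4 (0.35 log units; beyond the scatter) against prop-1-en-1-yl and a 3.5-fold higher number from compound 1 to compound 4 (0.54 log units; beyond the scatter) against 2-methylprop-1-en-1-yl, so the gap seen with 4-iodophenyl does not depend on iodine alone. No measurement available here explains why iodo and trifluoromethyl give such similar numbers.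

As far as these compounds go, whether an amine or a carboxylic acid at this ring position would also leave the number unchanged remains open. So does whether a cyclohexyl group on the carbonyl carbon would fall nearer the phenyl amides or the smaller groups.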